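Ethoxycarbonyl in Place of Propyl on the Shared Core

A few compounds are considered here, and "the series" means these few. Any claim that something is new, unique, unknown or untested is made for them only; others in the source may bear on it.

Of the compounds shown here, three have been tested in an ADME assay on HeLa cells (Homo sapiens) for cytotoxicity, read by sulforhodamine B assay, with a stated time of 48 h, tested at 10 uM; a higher number here means more inhibition at the concentration tested (going by the name of the read-out), a lower number less inhibition. Compound 1 `COc1nc2ccc(Br)cc2cc1C(c1ccccc1)n1cc(-c2cccc(F)c2)nn1` gives 9.04%. Compound 2 `CCCCCCCCc1cn(C(c2ccccc2)c2cc3cc(Br)ccc3nc2OC)nn1` gives 0.1%, and compound 3 `CCCc1cn(C(c2ccccc2)c2cc3cc(Br)ccc3nc2OC)nn1` gives -2.25%. Compound 3 therefore holds the lowest of the three numbers: its nearest neighbour is compound 2, which lies within the scatter, while compound 1 lies beyond it, as the step of a number 11.3 percentage points lower from compound 1 to compound 3 (beyond the scatter) shows.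

Compound 4 `CCOC(=O)c1cn(C(c2ccccc2)c2cc3cc(Br)ccc3nc2OC)nn1` differs from compound 3 by ethoxycarbonyl in place of propyl on an aromatic carbon. The measured steps that touch the same aromatic carbon are a number 11.3 percentage points lower from compound 1 to compound 3 (beyond the scatter), a number 8.9 percentage points lower from compound 1 to compound 2 (within the scatter) and a number 2.4 percentage points lower from compound 2 to compound 3 (within the scatter). These show that moving from 3-fluorophenyl to either chain at this position lowers the number only modestly, and that the two chains do not differ beyond the scatter. For the measured compounds named here, no measured step involves an ethoxycarbonyl group, so its effect is unknown; with all three numbers near zero, the expected step of a number 4.3 percentage points higher from compound 3 to compound 4 (within the scatter) is small, and compound 4 is estimated at 2%, between -8% and 12%.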

Compound 4, a percentage reported as inhibition, at one concentration (the size of the read-out at that concentration, not a potency): -3.67%
Compound 4: middle estimate off by 5.7 percentage points, on the high side, within the range that was stated.
By their numbers in this assay, from the lowest: compounds 4, 3, 2 and 1 (each within the scatter of the next, the first and the last beyond it).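

Ethoxycarbonyl brings a carbonyl and hydrogen-bond acceptors to this aromatic carbon, yet in this assay the change reads as a number 1.4 percentage points lower from compound 3 to compound 4 (within the scatter) and, against the longer chain, as a number 3.8 percentage points lower from compound 2 to compound 4 (within the scatter) so this group cannot be told apart from either the propyl or the octyl chain. The widest gap is to the ring-bearing compound, a number 12.7 percentage points lower from compound 1 to compound 4 (beyond the scatter) but this gives no clean split between 3-fluorophenyl and the other groups, since compound 2 goes against it with a number 8.9 percentage points lower from compound 1 to compound 2 (within the scatter) as its step from compound 1. Nothing available explains why these numbers fall as they do.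

On these data alone, it remains open whether an amine or a carboxylic acid on this carbon would move the number beyond the scatter from compound 4. As far as these compounds go, it is also open whether an unsubstituted phenyl ring here would match 3-fluorophenyl.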